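Ortho Fluoro on the Pendant Phenyl of a Quinazoline Amide

The compounds below may be only part of what the source reports. "The series", "measured", "known", "first", "only" and "open" are said of these compounds alone.

Measured compounds:
- compound 1, `CCN(Cc1ccccc1)C(=O)c1nc(-c2ccccc2Cl)c2ccccc2n1`: 0.235 nM
- compound 2, `CCN(Cc1ccccc1)C(=O)c1nc(-c2ccc(Cl)cc2)c2ccccc2n1`: 0.762 nM
- compound 3, `CN(Cc1ccccc1)C(=O)c1nc(-c2ccccc2)c2ccccc2n1`: 3.99 nM

Among the three measured compounds, compound 3 gives the highest number in an assay on cell membranes from kidney for displacement of a labelled ligand from Translocator protein (Rattus norvegicus) (a lower number here means a stronger inhibitor, a higher number a weaker inhibitor), so it is the weakest inhibitor of the set; compound 2 sits nearer to it and compound 1 furthest away. The unmeasured compound 4, `CN(Cc1ccccc1)C(=O)c1nc(-c2ccccc2F)c2ccccc2n1`, arises from compound 3 by a single change, (fluoro in place of hydrogen on an aromatic carbon); at the level of the whole group this reads as phenyl to 2-fluorophenyl, the new atom sitting ortho to a large group.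

For the measured compounds named here, no measured step adds a halogen to an unsubstituted phenyl here. Going by the values given here, the only step that bears on the position is a 3.2-fold higher number from compound 1 to compound 2 (0.51 log units; beyond the scatter), which shows that a chloro group ortho to the large group gives a lower number than the same group in the 4-position. Compound 1, carrying the ortho chloro, also shows the lowest number of all three, though it differs from compound 3 in two places. A fluoro group is smaller than chloro, so a gentler shift in the same direction is expected for compound 4: a lower number than compound 3, modest in size, a 2.7-fold lower number from compound 3 to compound 4 (0.42 log units; beyond the scatter). Compound 4 is therefore estimated at 1.5 nM, within a range from 0.5 nM to 4.5 nM.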

Compound 4, inhibition constant: 1.11 nM
Beside the measured number, compound 4's estimate is 1.4-fold (0.13 log units) above it; the measured number falls inside the stated range.
By their numbers in this assay, from the lowest: compound 1; then compounds 2 and 4 (each within the scatter of the next); then compound 3.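

For the compounds shown here, this is the first step in the set that adds a halogen to an unsubstituted phenyl, and in this assay it gives a 3.6-fold lower number from compound 3 to compound 4 (0.56 log units; beyond the scatter). The earlier compounds shown here could only compare two placements of chloro, and the step from compound 3 to compound 1 could not be read cleanly since those two differ in two places. Here the whole difference is one fluorine atom, with phenyl becoming 2-fluorophenyl and the rest of the molecule unchanged, so this single heavy atom is enough to move the number beyond the usual scatter; no measurement available here gives a reason for this shift.

The compounds shown leave open how a methyl, methoxy or trifluoromethyl group at this same place would compare with fluoro, and how 2-chlorophenyl would compare on the same methyl amide. They also leave open whether adding fluoro gives a step of similar size when the amide carries an ethyl group in place of the methyl group.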